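One Fluorine Step Repeated on a Second Scaffold

This account rests on a few compounds, and the source may have more. Where it says the series, first, only, none or still open, it means among the compounds named here.

Compound 1, `c1ccc(Cc2[nH]cnc3ncnc2-3)cc1`, gives 2% in an assay on isolated protein for inhibition of Ca2+/calmodulin-dependent protein kinase II (CaM kinase II) (Rattus norvegicus), tested at 30 uM; on this read-out lower numbers stand for less inhibition and higher numbers for more inhibition at the one concentration tested (going by the name of the read-out).
Compound 2, `Fc1ccc(Cc2[nH]cnc3ncnc2-3)cc1`, gives 8% in this assay.
Compound 3, `CSc1ccc(-c2nc3c(Sc4ccccc4)ncnc3n2C)cc1`, gives 0% in this assay.

The three measured compounds all sit at the low end of this assay. Compound 1 and compound 2 share a core and differ only by fluoro in place of hydrogen on an aromatic carbon. This change gave a number 6 percentage points higher from compound 1 to compound 2 (within the scatter), so the two numbers cannot be told apart.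

Compound 3 carries a different core; the difference between its core and the core of compound 1 is not broken down here. Its number is the lowest of the three, but within the scatter of both of the others.

Compound 4, `CSc1ccc(-c2nc3c(Sc4ccc(F)cc4)ncnc3n2C)cc1`, has not yet been measured. It differs from compound 3 by fluoro in place of hydrogen on an aromatic carbon. The place of the change reads the same as for the pair compound 1 and compound 2, so this is the same change made on the second core.

For compound 4 the expected step is a number 4 percentage points higher from compound 3 to compound 4 (within the scatter), a step of about the same size as the earlier one, because a number 6 percentage points higher from compound 1 to compound 2 (within the scatter) stayed within the scatter and compound 3 itself gives 0%. On that basis compound 4 is estimated at 4% in this assay, with a likely range from -6% to 14%.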

Compound 4, a percentage reported as inhibition, at one concentration (the size of the read-out at that concentration, not a potency): 7%
Estimate against measurement, compound 4: 3 percentage points below, and the stated range covers the measured number.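

Fluoro in place of hydrogen on an aromatic carbon, here phenylsulfanyl to (4-fluorophenyl)sulfanyl, gave a number 7 percentage points higher from compound 3 to compound 4 (within the scatter) in this assay, and the comparison with the first core reads as follows: the same change on two cores in this assay, a number 6 percentage points higher (within the scatter) from compound 1 to compound 2 and a number 7 percentage points higher (within the scatter) from compound 3 to compound 4, 1 percentage points apart, within the scatter of two such steps. As far as this read-out can tell, the change carries from the core of compound 1 to the core of compound 3 with no difference between the two steps. It does not show that fluoro raises inhibition on either core: each step lies within the scatter, all four compounds sit at the low end of the read-out at the one concentration tested, and the agreement is therefore one between two small steps rather than a shared gain.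

The compounds shown leave open whether another group at this place on the ring, such as chloro, methoxy or an amine, would give a step beyond the scatter on either core. They also leave open whether the fluoro step would read the same on a core that starts from a clearly higher number in this assay, where a real difference between cores could be told from the scatter.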